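The source may hold more compounds than are shown below. What is called first, only, known or untested is meant among the compounds shown, and "the series" means these compounds.

Measured in a physicochemical assay for lipophilicity, measured as octanol-water partition, at pH 7.4; a lower number here means a more polar compound, a higher number a more lipophilic compound:
- Compound 1 `CC(C)c1noc(N2CCC(Oc3cc(N4CCc5cc(N6CCCCC6=O)ccc54)ncn3)CC2)n1`: 3.8
- Compound 2 `CC(C)c1noc(N2CCC(Oc3cc(N4CCc5cc(N6CCCS6(=O)=O)ccc54)ncn3)CC2)n1`: 3.2
- Compound 3 `CC(C)c1noc(N2CCC(Oc3cc(N4CCc5cc([S+]([O-])CCO)ccc54)ncn3)CC2)n1`: 2.7

Compound 3 has the lowest number of the three in this assay. Compound 4 `CC(=O)N(C)c1ccc2c(c1)CCN2c1cc(OC2CCN(c3nc(C(C)C)no3)CC2)ncn1` carries acetyl(methyl)amino at the same aromatic carbon: a group of 5 heavy atoms (3 carbon, 1 nitrogen, 1 oxygen; no ring) in place of a group of 5 heavy atoms (2 carbon, 2 oxygen, 1 sulfur; no ring), on an aromatic carbon.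

The closest evidence is a number 1.10 log units lower from compound 1 to compound 3 (beyond the scatter), a large step, and a number 0.50 log units lower from compound 2 to compound 3 (beyond the scatter), a modest one. Like the group in compound 1, the entering group holds nitrogen and no sulfur, but it has no ring. Only part of a number 1.10 log units lower from compound 1 to compound 3 (beyond the scatter) is therefore expected to be recovered, which points to a modest rise. The expected step is a number 0.60 log units higher from compound 3 to compound 4 (beyond the scatter). Compound 4 is estimated at 3.3, within a range of 2.9 to 3.7.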

Compound 4, distribution coefficient: 3.7
The estimate for compound 4 lay 0.40 log units below the measured number; low and high end bracket the measured number.
By their numbers in this assay, from the lowest: compound 3; then compound 2; then compounds 4 and 1 (each within the scatter of the next).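

In this assay the ring is not needed at this aromatic carbon: acetyl(methyl)amino in place of 2-oxopiperidin-1-yl gives a number 0.10 log units lower from compound 1 to compound 4 (within the scatter) and so reads the same as the ring-bearing group. Heavy-atom count alone does not set the number, since swapping one group of 5 heavy atoms for another gives a number 1.00 log units higher from compound 3 to compound 4 (beyond the scatter) while losing the sulfur-containing ring gives a number 0.50 log units higher from compound 2 to compound 4 (beyond the scatter) for a smaller group. Nothing at hand explains these differences.

Where a carboxylic acid or a primary amine at this aromatic carbon would stand against compound 3 remains open.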